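A few compounds are considered here, and "the series" means these few. Any claim that something is new, unique, unknown or untested is made for them only; others in the source may bear on it.

Compound 3 (`O=C(N/N=C/c1ccc([N+](=O)[O-])cc1)Nc1ccc(Oc2ccnc3[nH]ccc23)c(F)c1`) gives 4000 nM in a functional assay on MCF7 cells (Homo sapiens) for antiproliferative activity, read by MTT assay, with a stated time of 72 h; a lower number here means a stronger inhibitor, a higher number a weaker inhibitor. Compound 1 (`O=C(N/N=C/c1ccccc1)Nc1ccc(Oc2ccnc3[nH]ccc23)c(F)c1`) has hydrogen where compound 3 has its nitro group, and compound 1 gives 2380 nM. The measurements show a 1.7-fold higher number from compound 1 to compound 3 (0.23 log units; within the scatter), so these two compounds sit level. Compound 2 (`O=C(N/N=C/c1cccc(Br)c1)Nc1ccc(Oc2ccnc3[nH]ccc23)c(F)c1`) gives 49 nM, and the comparison shows an 82-fold higher number from compound 2 to compound 3 (1.91 log units; beyond the scatter). Compound 3 therefore shares the high end of this small set with compound 1, well away from compound 2.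

The next compound, compound 4 (`O=C(N/N=C/c1ccc(Cl)c(Cl)c1)Nc1ccc(Oc2ccnc3[nH]ccc23)c(F)c1`), differs from compound 3 in one group: 3,4-dichlorophenyl in place of 4-nitrophenyl on a carbon with a double bond to nitrogen. Put simply, 3,4-dichlorophenyl stands in place of 4-nitrophenyl on a carbon with a double bond to nitrogen.

The closest guide is the bromo group, a halogen like chlorine. Adding it gave a 49-fold lower number from compound 1 to compound 2 (1.69 log units; beyond the scatter), whereas adding the nitro group gave only a 1.7-fold higher number from compound 1 to compound 3 (0.23 log units; within the scatter). Among the compounds with values here, no chlorine compound has been measured, however, and three compounds cannot establish a firm rule. A large step towards a lower number is therefore expected in this assay, though the uncertainty is wide. The expected change is a 16-fold lower number from compound 3 to compound 4 (1.20 log units; beyond the scatter). For compound 4 the estimated value is 250 nM, with an expected range from 40 nM to 1500 nM.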

Compound 4, half-maximal inhibitory concentration: 998 nM
For compound 4 the middle estimate is 4.0-fold (0.60 log units) below the measured one, within the range that was stated.
By their numbers in this assay, from the lowest: compound 2; then compound 4; then compounds 1 and 3 (each within the scatter of the next).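

In this assay a halogen on the phenyl ring at this place does not by itself bring the large drop seen with bromo: 3,4-dichlorophenyl in place of phenyl gives a much smaller step (a 2.4-fold lower number from compound 1 to compound 4 (0.38 log units; beyond the scatter)) than the bromo group gave (a 49-fold lower number from compound 1 to compound 2 (1.69 log units; beyond the scatter)). Compound 4 also stays well behind the 3-bromophenyl compound (a 20-fold higher number from compound 2 to compound 4 (1.31 log units; beyond the scatter)), so the outcome here depends on which halogen-bearing ring is present, not merely on whether the ring carries a halogen. The move away from 4-nitrophenyl still gives a real improvement (a 4.0-fold lower number from compound 3 to compound 4 (0.60 log units; beyond the scatter)), and so compound 2 and compound 4, the two halogen-bearing compounds, both have lower numbers than compound 1 and compound 3.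

Compound 4 differs from compound 2 both in the kind of halogen and in the number of halogens on the ring, so these two effects cannot be separated, and a phenyl ring bearing a single chlorine would be needed to do that. How a methoxy group or an amine on this ring would compare stays open, and no independent measurement is available to explain the differences seen here.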